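A Chloro Substituent on the Sulfonyl Ring of Compound 2

A few compounds are considered here, and "the series" means these few. Any claim that something is new, unique, unknown or untested is made for them only; others in the source may bear on it.

Compound 1 `Cc1ccc(-n2cc(NC(=O)c3ccc(NS(=O)(=O)c4ccccc4)cc3)cn2)cc1`: 10900 nM
Compound 2 `COc1ccc(-n2cc(NC(=O)c3ccc(NS(=O)(=O)c4ccccc4)cc3)cn2)cc1`: 25600 nM
Compound 3 `COc1cccc(-n2cc(NC(=O)c3ccc(NS(=O)(=O)c4ccccc4)cc3)cn2)c1`: 28400 nM

Of the compounds shown here, three sharing one core have been measured in a functional assay on MCF7 cells (Homo sapiens) for inhibition, read by MTT assay, with a stated time of 48 h; on this read-out lower numbers stand for stronger inhibition and higher numbers for weaker inhibition. Compound 2 gives 25600 nM and stands within the scatter of compound 3, as the step of a 1.1-fold higher number from compound 2 to compound 3 (0.05 log units; within the scatter) shows, while it lies beyond the scatter from compound 1, the step of a 2.3-fold higher number from compound 1 to compound 2 (0.37 log units; beyond the scatter) being a modest one. The third measured step, a 2.6-fold higher number from compound 1 to compound 3 (0.42 log units; beyond the scatter), is of similar size.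

Compound 4 `COc1ccc(-n2cc(NC(=O)c3ccc(NS(=O)(=O)c4ccc(Cl)cc4)cc3)cn2)cc1` differs from compound 2 by chloro in place of hydrogen on an aromatic carbon. Among the measured compounds shown here, none of the measured steps touches this place: all three concern the aryl group on the aromatic nitrogen of the core, whereas the change here sits on the phenylsulfonyl group. The measured steps therefore give no direct guide, and they only show that exchanges among the three compounds stay modest or within the scatter.

On that basis compound 4 is expected to give 20000 nM, with a range of 8000 nM to 50000 nM. The step this estimate means, a 1.3-fold lower number from compound 2 to compound 4 (0.11 log units; within the scatter), is expected to lie within the scatter.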

Compound 4, half-maximal inhibitory concentration: 15600 nM
Beside the measured number, compound 4's estimate is 1.3-fold (0.11 log units) above it, within the range that was stated.
By their numbers in this assay, from the lowest: compounds 1, 4, 2 and 3 (each within the scatter of the next, the first and the last beyond it).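

In this assay, among the compounds shown here, the step of a 1.6-fold lower number from compound 2 to compound 4 (0.22 log units; within the scatter) is the first measured change on the phenylsulfonyl group, since all the earlier steps concerned the aryl group on the aromatic nitrogen of the shared core. It shows that, with the 4-methoxyphenyl group of compound 2 in place, exchanging phenyl for 4-chlorophenyl on the sulfonyl group, which puts a single chlorine atom para to a large group, does not move the number beyond the scatter. The compounds shown offer no measurement that could explain this outcome.

On these data alone, one substituent at one place is a narrow test, so it remains open whether chloro on this ring would give a similar result when combined with the 4-methylphenyl group of compound 1, whose number stands beyond the scatter from that of compound 2. As far as these compounds go, it also remains open whether a quite different group at this place, such as an amine or a carboxylic acid, would stay within the scatter of compound 2 or produce a clear step in either direction.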